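Replacing the Furan Amide Arm with an Aminobenzimidazole

The source may hold more compounds than are shown below. What is called first, only, known or untested is meant among the compounds shown, and "the series" means these compounds.

Measured compounds:
- compound 1, `Cc1cc(C)cc(S(=O)(=O)c2c(C(=O)NC(C)C(=O)NCc3ccco3)[nH]c3ccc(Cl)cc23)c1`: in an ADME assay on MT4 cells (Homo sapiens) for cytotoxicity, read by MTT assay (on this read-out higher numbers stand for lower toxicity in this test and lower numbers for higher toxicity in this test), compound 1 gives 24200 nM
- compound 2, `Cc1cc(C)cc(S(=O)(=O)c2c(C(=O)NC(c3ccc(Cl)cc3)C3CC3)[nH]c3ccc(Cl)cc23)c1`: for compound 2 only a limit is reported, > 47300 nM
- compound 3, `Cc1cc(C)cc(S(=O)(=O)c2c(C(=O)NC(C)C(=O)NCc3ccncn3)[nH]c3ccc(Cl)cc23)c1`: compound 3 gives 28100 nM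

Compound 1 has the lowest of the two numbers in this series; the nearest is compound 3, with a 1.2-fold higher number from compound 1 to compound 3 (0.06 log units; within the scatter). Compound 2 sits at the limit of > 47300 nM in this assay, at which 1 of the 3 values shown sits.

Compound 4, `Cc1cc(C)cc(S(=O)(=O)c2c(C(=O)NCc3ccc4nc(N)[nH]c4c3)[nH]c3ccc(Cl)cc23)c1`, is not yet measured. Its change from compound 1 is a group of 11 heavy atoms (8 carbon, 3 nitrogen; one five-membered aromatic ring with 2 hetero atoms, one six-membered aromatic ring of carbon only) in place of a group of 11 heavy atoms (8 carbon, 1 nitrogen, 2 oxygen; one five-membered aromatic ring with 1 hetero atom), on an amide-type nitrogen.

Two measured steps alter the same position and bear on this one. Exchanging the whole group on the amide nitrogen gave an at least 1.9-fold higher number from compound 1 to compound 2 (0.29 log units; that floor lies within the scatter), and exchanging only the ring at the end of the chain gave a 1.2-fold higher number from compound 1 to compound 3 (0.06 log units; within the scatter). Both fall within the scatter, so the assay appears little moved by what is attached at this nitrogen. Accordingly, compound 4 is expected to show no step beyond the scatter, a 1.2-fold higher number from compound 1 to compound 4 (0.09 log units; within the scatter), though with a fair chance of reaching a limit as compound 2 did. Compound 4 is estimated at 30000 nM, with a range from 12000 nM to 60000 nM.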

Compound 4, half-maximal cytotoxic concentration: 5890 nM
The estimate for compound 4 lay 5.1-fold (0.71 log units) above the measured number, outside the stated range (below it).
By their numbers in this assay, from the lowest: compound 4; then compounds 1 and 3 (each within the scatter of the next). At a limit, above all of these: compound 2.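

In this assay, the earlier exchanges on the amide-type nitrogen had stayed within the scatter, which made this position look indifferent, but the group entering in compound 4 moves the number beyond the scatter, with a 4.1-fold lower number from compound 1 to compound 4 (0.61 log units; beyond the scatter) and a 4.8-fold lower number from compound 3 to compound 4 (0.68 log units; beyond the scatter). The same group also gives an at least 8.0-fold lower number from compound 2 to compound 4 (0.90 log units; beyond the scatter), so compound 4 has the lowest number of the four, with its steps to all three others printed as beyond the scatter, and in this test the lower number stands for higher toxicity. Compound 2 is held at a limit and not at a number: the limit of > 47300 nM in this assay, at which 1 of the 4 values shown sits.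

Compound 4 exchanges the whole group on the amide-type nitrogen in one step, so the compounds shown cannot tell whether the lower number goes with the amino group it carries, with its pair of aromatic rings, or with the loss of the 1-(((furan-2-yl)methyl)carbamoyl)ethyl chain. A methyl group in place of that amino group, or a plain benzyl group on the same nitrogen, would separate these, and the compounds shown include neither.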